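Thiophene for pyridine in a ubiquitin hydrolase inhibitor series

The source may hold more compounds than are shown below. What is called first, only, known or untested is meant among the compounds shown, and "the series" means these compounds.

Measured compounds:
Compound 1 `Cn1nc2c(=O)n(CC3(O)CCN(Cc4ccc(-c5ccncc5)cc4Cl)CC3)cnc2c1-c1ccc(CN)cc1` gives 257 nM in an assay on isolated protein for inhibition of ubiquitin carboxyl-terminal hydrolase 7 (Homo sapiens), with stated times of 30 min and 2 h; a lower number here means a stronger inhibitor, a higher number a weaker inhibitor.
Compound 2 `Cn1nc2c(=O)n(CC3(O)CCN(Cc4ccc(-c5ccco5)cc4Cl)CC3)cnc2c1-c1ccc(CNC=O)cc1` gives 20.9 nM in this assay.
Compound 3 `CCCNCc1ccc(-c2c3ncn(CC4(O)CCN(Cc5ccc(-c6ccco6)cc5Cl)CC4)c(=O)c3nn2C)cc1` gives 43.9 nM in this assay.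

Compound 1 stands highest of the three numbers in this assay, that is, it is the weakest inhibitor shown; compound 3 is nearest to it and compound 2 furthest, both beyond the scatter. Within the data shown here, the only step measured in one place, a 2.1-fold higher number from compound 2 to compound 3 (0.32 log units; beyond the scatter), concerns the amine substituent and not the aromatic ring.

Compound 4 `Cc1ccc(-c2ccc(CN3CCC(O)(Cn4cnc5c(-c6ccc(CN)cc6)n(C)nc5c4=O)CC3)c(Cl)c2)s1` is not yet measured. It differs from compound 1 as follows: 5-methylthiophen-2-yl in place of pyridin-4-yl on an aromatic carbon. Among the measured compounds shown here, no measured step bears on this change. Compounds 2 and 3 differ from compound 1 in more than one place, so their lower numbers cannot be assigned to the aromatic ring alone. A modest step in this assay is therefore expected, its direction uncertain, with the range kept wide.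

For compound 4 the expected value is 160 nM (range 50 nM to 500 nM), which as a step means a 1.6-fold lower number from compound 1 to compound 4 (0.21 log units; within the scatter).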

Compound 4, half-maximal inhibitory concentration: 101 nM
Compound 4: middle estimate off by 1.6-fold (0.20 log units), on the high side; measured number inside the range.
By their numbers in this assay, from the lowest: compound 2; then compound 3; then compound 4; then compound 1.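

In this assay, putting 5-methylthiophen-2-yl in place of pyridin-4-yl gives a 2.5-fold lower number from compound 1 to compound 4 (0.41 log units; beyond the scatter), and this is the only step shown at this position with the rest of the molecule unchanged. It shows that the ring on this aromatic carbon, para to a large group, affects the read-out on its own, apart from any change at the amine. Both groups have the same heavy-atom count, yet nothing shown explains the step.

As far as these compounds go, the step swaps the ring and adds a methyl group together, so the share of each stays open, and a plain thiophen-2-yl group on the core of compound 1 would separate them. From the compounds shown here alone, how furan-2-yl compares on that same core also stays open, as compound 2 and compound 3 differ from compound 1 in more than one place.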